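The compounds below may be only part of what the source reports. "The series", "measured", "known", "first", "only" and "open" are said of these compounds alone.

Measured so far in an ADME assay on J774 cells (Mus musculus) for cytotoxicity; on this read-out higher numbers stand for an effect only at larger amounts of compound and lower numbers for an effect already at smaller amounts:
- Compound 1 `COC(=O)c1c[nH]c2ccccc2c1=O`: > 20000 nM (a limit)
- Compound 2 `COC(=O)c1c[nH]c2cc(Cl)ccc2c1=O`: > 20000 nM (a limit)

Compound 2 has no exact number in this assay, only the limit > 20000 nM. Compound 1 is also known only by a limit, > 20000 nM. The data therefore show (the limit of > 20000 nM in this assay, at which 2 of the 2 values shown sit).

The next compound, compound 3 `COC(=O)c1c[nH]c2cc(F)ccc2c1=O`, keeps the shared core and differs from compound 2 in a single group: fluoro in place of chloro on an aromatic carbon. In short, fluoro takes the place of chloro on an aromatic carbon. Going by the values given here, the only measured step that bears on this change is also a swap on an aromatic carbon: a step that the two limits leave unreadable from compound 1 to compound 2. That step has no readable size, so it offers no sign of a real shift in either direction. No step beyond the usual scatter is therefore expected in this assay.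

The estimated change is a step that the limit leaves unreadable from compound 2 to compound 3. Compound 3 is expected at about 25000 nM, with an estimated range of 12000 nM to 50000 nM, and the result may well come back only as a limit.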

Compound 3, half-maximal effective concentration: > 20000 nM
Compound 3: only a limit was reported (the forecaster's own chance of this, stated with the estimate: 85%); the middle value lies beyond the limit too.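

No step can be read between compound 1, compound 2 and compound 3 in this assay, because all three are known only by the same limit: the limit of > 20000 nM in this assay, at which 3 of the 3 values shown sit. The compounds shown leave open where each one's true value lies past that limit, and whether hydrogen, chloro or fluoro on that aromatic carbon makes any difference.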